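The compounds below may be only part of what the source reports. "The series", "measured", "known", "first", "only" and "open" are said of these compounds alone.

Compound 1 `C/C=C/C(=O)N1CC(Oc2ccc(Oc3c(-c4ccc(F)cc4)sc4cc(O)ccc34)cc2)C1` gives 28000 nM in a functional assay on MCF7 cells (Homo sapiens) for antiproliferative activity, read by CCK-8 assay, with a stated time of 48 h (a higher number here means a weaker inhibitor, a lower number a stronger inhibitor), the highest of the two numbers recorded so far. Within the data shown here, compound 2 `C=CC(=O)N1CC(Oc2ccc(Oc3c(-c4ccc(F)cc4)sc4cc(O)ccc34)cc2)C1` gives 23500 nM in this assay; the only measured step, a 1.2-fold lower number from compound 1 to compound 2 (0.08 log units; within the scatter), alters the same group on the carbonyl carbon and stays within the scatter. Compound 3 `C=C(C)C(=O)N1CC(Oc2ccc(Oc3c(-c4ccc(F)cc4)sc4cc(O)ccc34)cc2)C1` differs from compound 1 by 1-methylethenyl in place of prop-1-en-1-yl on a carbonyl carbon. Among the measured compounds shown here, that single measured step is the only guide, and it moved little, so no shift beyond the scatter is expected in this assay, meaning an expected no change at the digits printed from compound 1 to compound 3 (within the scatter). Compound 3 is therefore estimated at 28000 nM, with a range from 12000 nM to 65000 nM.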

Compound 3, half-maximal inhibitory concentration: > 25000 nM
Compound 3 gave a limit, no number (the forecaster's own chance of this, stated with the estimate: 10%); the middle value does not contradict the limit.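

In this assay, compound 3 gives a limit, not a number: the limit of > 25000 nM in this assay, at which 1 of the 3 values shown sits.

Placing methyl in place of hydrogen on a double-bonded chain carbon bound to a carbonyl carbon gives an at least 1.0-fold higher number from compound 2 to compound 3 (0.02 log units; that floor lies within the scatter), so this change shows no gain in inhibition, although the full size of the step remains unknown. The step between the two isomeric chains, prop-1-en-1-yl and 1-methylethenyl, cannot be read.

As far as these compounds go, how far compound 3 lies beyond its limit remains open. So does whether an amine on the chain, or a longer chain, would lower the number.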